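The compounds below may be only part of what the source reports. "The series", "measured", "known", "first", "only" and "open" are said of these compounds alone.

Measured so far:
Compound 1 `O=C(Nc1nc2ccc(Cl)cc2s1)c1cn(-c2ccccc2)nc1-c1ccc(Cl)cc1`: 5870 nM
Compound 2 `COc1ccc2nc(NC(=O)c3cn(-c4ccccc4)nc3-c3ccc(Cl)cc3)sc2c1`: 21200 nM

In a functional assay on U-87MG ATCC cells for cytotoxicity against U-87 MG (Homo sapiens), read by MTT assay, with a stated time of 72 h (a higher number here means a weaker inhibitor, a lower number a stronger inhibitor), compound 2 stands at the highest of the two numbers, with compound 1 the nearest at a lower number. Compound 3 `Cc1ccc2nc(NC(=O)c3cn(-c4ccccc4)nc3-c3ccc(Cl)cc3)sc2c1` differs from compound 2 only in that (methyl in place of methoxy on an aromatic carbon). One measured step at the same place bears on this: a 3.6-fold higher number from compound 1 to compound 2 (0.56 log units; beyond the scatter), a modest rise when methoxy replaced chloro. Methyl is a smaller change from chloro than methoxy was, so a modest move back toward a lower number is expected for compound 3, a 1.9-fold lower number from compound 2 to compound 3 (0.28 log units; within the scatter), with an estimate of 11000 nM and a range from 4000 nM to 30000 nM.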

Compound 3, half-maximal inhibitory concentration: 33200 nM
Compound 3: middle estimate off by 3.0-fold (0.48 log units), on the low side; measured number above the stated range.
By their numbers in this assay, from the lowest: compound 1; then compounds 2 and 3 (each within the scatter of the next).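

In this assay, going from methoxy to methyl gives a 1.6-fold higher number from compound 2 to compound 3 (0.19 log units; within the scatter), so these two groups cannot be told apart here. Chloro now stands apart from both: methyl in its place gives a 5.7-fold higher number from compound 1 to compound 3 (0.75 log units; beyond the scatter), so the rise seen earlier with methoxy is not unique to that group, at least among these three compounds. Nothing measured here explains why chloro differs.

As far as these compounds go, whether an amine or a carboxylic acid at this place would behave like chloro or like methoxy and methyl remains open. So does whether any group here could give a lower number than compound 1.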